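Ortho-Halogen Swap on the Benzylamine: Fluoro to Chloro

The source may hold more compounds than are shown below. What is called first, only, known or untested is meant among the compounds shown, and "the series" means these compounds.

Compound 2 `COc1cnc(-c2ccccn2)nc1NCc1ccccc1F` was measured in an in vitro ADME assay on microsomes from liver (Homo sapiens) for metabolic stability, read by LC-MS, tested at 0.05 uM (a lower number here means slower removal, a higher number faster removal of the compound), where compound 2 gives 61 mL/min/kg. Among the two measured compounds it has the higher number, yet its nearest neighbour, compound 1 `COc1cnc(-c2ccccn2)nc1NCc1ccccc1C`, lies close: in this assay compound 1 gives 55 mL/min/kg, and the step of a 1.1-fold higher number from compound 1 to compound 2 (0.04 log units; within the scatter) lies within the scatter, so no order between the two can be claimed.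

The next compound, compound 3 `COc1cnc(-c2ccccn2)nc1NCc1ccccc1Cl`, differs from compound 2 as follows: chloro in place of fluoro on an aromatic carbon. For the measured compounds named here, only one measured step bears on this change, the one from compound 1 to compound 2, which exchanged one small group on the same aromatic carbon for another and moved the number by a 1.1-fold higher number from compound 1 to compound 2 (0.04 log units; within the scatter). On that basis the author expects the exchange of one halogen for another at this position to leave this assay essentially unchanged, with no step beyond the scatter in either direction.

Compound 3 is therefore estimated at 60 mL/min/kg in this assay, within a range of 35 mL/min/kg to 100 mL/min/kg, an expected step of a 1.0-fold lower number from compound 2 to compound 3 (0.01 log units; within the scatter).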

Compound 3, clearance: 55 mL/min/kg
The estimate for compound 3 lay 1.1-fold (0.04 log units) above the measured number; the range from low to high includes it.
By their numbers in this assay, from the lowest: compounds 1, 3 and 2 (each within the scatter of the next).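

With chloro on this aromatic carbon, three different groups have now been read at one place on the shared core, and in this assay the step of a 1.1-fold lower number from compound 2 to compound 3 (0.04 log units; within the scatter) and the step of no change at the digits printed from compound 1 to compound 3 (within the scatter) both lie within the scatter. The earlier compounds shown here showed only that fluoro and methyl could not be told apart here; the new result extends this to a second halogen and to the direct exchange of methyl for chloro, so that methyl, fluoro and chloro, each ortho to a large group, cannot be placed in any order by their clearance. The data shown give no reason for this sameness.

What these three compounds leave open is whether a group of another kind at this place, such as methoxy, a nitrile or an amine, would give a step beyond the scatter. They also leave open what a bare hydrogen at this carbon would give, and whether chloro on a different carbon of the same ring would read the same.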